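Piperidine nitrogen substituent and Caco-2 permeability in the series

The source may report more compounds than this note shows. Statements on the series, on what has been measured and on what is new or still open speak of the compounds shown alone.

compound 1 `Cn1cncc1CN1CC(N(CC2CCN(C(=O)c3ccc(Cl)cc3)CC2)S(=O)(=O)c2ccccn2)Cc2cc(C#N)ccc21`: 0.5 10^-6 cm/s
compound 2 `Cn1cncc1CN1CC(N(CC2CCN(S(C)(=O)=O)CC2)S(=O)(=O)c2ccccn2)Cc2cc(C#N)ccc21`: 0.1 10^-6 cm/s
compound 3 `CC(=O)N1CCC(CN(C2Cc3cc(C#N)ccc3N(Cc3cncn3C)C2)S(=O)(=O)c2ccccn2)CC1`: 0.5 10^-6 cm/s

In an ADME assay on Caco-2 cells (Homo sapiens) for permeability, in the apical to basolateral direction (on this read-out higher numbers stand for higher permeability and lower numbers for lower permeability), compound 2 holds the lowest of the three numbers. The steps of a 5.0-fold lower number from compound 1 to compound 2 (0.70 log units; beyond the scatter) and a 5.0-fold higher number from compound 2 to compound 3 (0.70 log units; beyond the scatter) are each beyond the scatter, while the step of no change at the digits printed from compound 1 to compound 3 (within the scatter) is within it, so the methylsulfonyl analogue stands apart from the two carbonyl analogues.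

Compound 4 `CCNC(=O)N1CCC(CN(C2Cc3cc(C#N)ccc3N(Cc3cncn3C)C2)S(=O)(=O)c2ccccn2)CC1` differs from compound 2 by ethylcarbamoyl in place of methylsulfonyl on an amine nitrogen in a ring. The step that bears on this is a 5.0-fold higher number from compound 2 to compound 3 (0.70 log units; beyond the scatter), where methylsulfonyl also left the same ring nitrogen; the step of a 5.0-fold lower number from compound 1 to compound 2 (0.70 log units; beyond the scatter) points the same way. An upward step is therefore expected, and the expected size is a 3.0-fold higher number from compound 2 to compound 4 (0.48 log units; beyond the scatter). Compound 4 is estimated at 0.3 10^-6 cm/s, with a range from 0.1 10^-6 cm/s to 0.8 10^-6 cm/s.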

Compound 4, apparent permeability: 0.6 10^-6 cm/s
The estimate for compound 4 lay 2.0-fold (0.30 log units) below the measured number; the range from low to high includes it.
By their numbers in this assay, from the lowest: compound 2; then compounds 1, 3 and 4 (each within the scatter of the next).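

In this assay, a 6.0-fold higher number from compound 2 to compound 4 (0.78 log units; beyond the scatter) shows that ethylcarbamoyl, like the acetyl and (4-chlorophenyl)carbonyl groups, separates from methylsulfonyl on this ring nitrogen, leaving compound 2 alone at the low end. With a 1.2-fold higher number from compound 3 to compound 4 (0.08 log units; within the scatter) and a 1.2-fold higher number from compound 1 to compound 4 (0.08 log units; within the scatter) both within the scatter, ethylamino on the carbonyl carbon cannot be told apart from methyl or 4-chlorophenyl, even with the hydrogen-bond donor it brings. No measurement here accounts for the gap between methylsulfonyl and the carbonyl groups. Open, on these data alone, is whether a propylsulfonyl or 4-chlorophenylsulfonyl group on this nitrogen would stay with compound 2 or join the carbonyl analogues.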